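The compounds below may be only part of what the source reports. "The series", "measured", "known", "first", "only" and "open" are said of these compounds alone.

Compound 1 `CCn1cc(Nc2ncc3cccc(-c4ccc(OC)cc4)c3n2)cn1`: in an assay on isolated protein for inhibition of eIF-2-alpha kinase GCN2 (Homo sapiens) (a higher number here means a weaker inhibitor, a lower number a stronger inhibitor), compound 1 gives > 1000 nM, which is a limit of the assay and not a number.
Compound 2 `CNC(=O)[C@]1(C)CC[C@@H](Nc2ncc3c(Br)nn(-c4ccc(-c5nnc(C)o5)cc4)c3n2)C1`: in this assay compound 2 gives 16 nM.
Compound 3 `CNC(=O)[C@]1(C)CC[C@@H](Nc2ncc3c(Br)nn(-c4ccc(-c5cnc(C)s5)cc4)c3n2)C1`: in this assay compound 3 gives 27 nM.

Within the data shown here, of the two numbers obtained in this assay, compound 3 carries the higher one, but the only measured step, a 1.7-fold higher number from compound 2 to compound 3 (0.23 log units; within the scatter), lies within the scatter, so compound 2 and compound 3 cannot be told apart on these data. Compound 1 sits at the limit of > 1000 nM in this assay, at which 1 of the 3 values shown sits, and contributes no number.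

Compound 4 `CNC(=O)[C@]1(C)CC[C@@H](Nc2ncc3c(Br)nn(-c4ccc(-c5ncc(C)s5)cc4)c3n2)C1` differs from compound 3 by 5-methyl-1,3-thiazol-2-yl in place of 2-methyl-1,3-thiazol-5-yl on an aromatic carbon. Among the measured compounds shown here, the one step that bears on this place, a 1.7-fold higher number from compound 2 to compound 3 (0.23 log units; within the scatter), exchanged one five-membered heteroaryl for another and stayed within the scatter; the present change keeps the same atoms and only rejoins them. No shift beyond the scatter is therefore expected in this assay, in either direction. Compound 4 is expected to show a 1.1-fold higher number from compound 3 to compound 4 (0.05 log units; within the scatter). Compound 4 is estimated at 30 nM, with a likely range from 12 nM to 80 nM.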

Compound 4, half-maximal inhibitory concentration: 76 nM
The estimate for compound 4 lay 2.5-fold (0.40 log units) below the measured number; low and high end bracket the measured number.
By their numbers in this assay, from the lowest: compounds 2 and 3 (each within the scatter of the next); then compound 4. At a limit, above all of these: compound 1.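

In this assay, the aromatic carbon para to a large group proves sensitive to how the heteroaryl is joined, not only to which atoms it holds: with the same atoms, 5-methyl-1,3-thiazol-2-yl in place of 2-methyl-1,3-thiazol-5-yl gives a 2.8-fold higher number from compound 3 to compound 4 (0.45 log units; beyond the scatter), a modest loss. Among these compounds, the earlier exchange of one five-membered heteroaryl for another had stayed within the scatter, so this is the first change here that can be read as a weakening. The same group in place of 5-methyl-1,3,4-oxadiazol-2-yl gives a 4.8-fold higher number from compound 2 to compound 4 (0.68 log units; beyond the scatter), also modest.

On these data alone, whether an amine or a carboxylic acid in place of the methyl on the thiazole would shift the number in this assay stays open. Nothing among the data shown accounts for the difference between the two thiazoles.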